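Disulfide-linked series: half-life at neutral pH

This account rests on a few compounds, and the source may have more. Where it says the series, first, only, none or still open, it means among the compounds named here.

compound 1 `Cc1cn([C@H]2C[C@H](SSC(Cl)(Cl)Cl)[C@@H](CO)O2)c(=O)[nH]c1=O`, a limit only: < 0.0834 h
compound 2 `Cc1cn([C@H]2C[C@H](SSc3ccc([N+](=O)[O-])cc3)[C@@H](CO)O2)c(=O)[nH]c1=O`, a limit only: < 0.0834 h
compound 3 `CCCCCCCCSS[C@H]1C[C@H](n2cc(C)c(=O)[nH]c2=O)O[C@@H]1CO`, a limit only: < 0.0834 h

The read-out is a physicochemical assay for pharmacokinetics, at pH 7.2; a lower number here means that the compound disappears faster, a higher number that the compound lasts longer. None of the three compounds gives a number; every value is the limit of < 0.0834 h in this assay, at which 3 of the 3 values shown sit. Compound 3 therefore stands at a limit of the assay, not at a measured point. The steps a step that the two limits leave unreadable from compound 1 to compound 2, a step that the two limits leave unreadable from compound 1 to compound 3 and a step that the two limits leave unreadable from compound 2 to compound 3 are all unreadable, and no one of the three compounds can be placed above or below another.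

Compound 4 `Cc1cn([C@H]2C[C@H](SSCCO)[C@@H](CO)O2)c(=O)[nH]c1=O` differs from compound 3 by hydroxy in place of hexyl on a saturated chain carbon, two bonds along the chain from a sulfur. Going by the values given here, no measured step reads a size for any change on the sulfur, so nothing here gives a direction. Three different groups on that sulfur all left their compounds at the limit, and compound 4 is expected to do the same: the step that the limit leaves unreadable from compound 3 to compound 4 is estimated as none beyond the scatter. For compound 4 the expected value is 0.05 h, within 0.01 h to 0.3 h, most probably reported again only as a limit.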

Compound 4, half-life: < 0.0834 h
Compound 4 gave a limit, no number; the forecaster's own chance of this, stated with the estimate: 70%; the middle value does not contradict the limit.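

Going by these compounds alone, compound 4 joins compound 1, compound 2 and compound 3 at one limit, so no step from any of them to compound 4 can be read: the limit of < 0.0834 h in this assay, at which 4 of the 4 values shown sit. The compounds shown leave open how long any of these disulfides actually lasts, and whether the group on the sulfur changes that at all.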